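The source may hold more compounds than are shown below. What is called first, only, known or untested is meant among the compounds shown, and "the series" means these compounds.

Measured compounds:
compound 1, `COC(=O)c1sc2cc(F)ccc2c1C1CCN(CC(O)Cn2nc(-c3ccc(C(F)(F)F)cc3)c3c2CCN(C(C)=O)C3)CC1`, 140 nM
compound 2, `CS(=O)(=O)N1CCc2c(c(-c3ccc(Br)cc3)nn2CC(O)CN2CCC(c3c[nH]c4ccc(Cl)cc34)CC2)C1`, 54 nM
compound 3, `COc1ccc2[nH]cc(C3CCN(CC(O)Cn4nc(-c5ccc(C(F)(F)F)cc5)c5c4CCN(S(C)(=O)=O)C5)CC3)c2c1`, 29 nM

In an assay on isolated protein for inhibition of cathepsin S (Homo sapiens) (a lower number here means a stronger inhibitor, a higher number a weaker inhibitor), compound 3 holds the lowest of the three numbers shown. Its nearest neighbour is compound 2, whose number stands within the usual scatter of that of compound 3, so the two cannot be told apart. Compound 1 stands furthest away, with a number beyond the scatter, so compound 3 and compound 1 are clearly separated in this assay.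

Compound 4, `CS(=O)(=O)N1CCc2c(c(-c3ccc(C(F)(F)F)cc3)nn2CC(O)CN2CCC(c3c[nH]c4ccncc34)CC2)C1`, is not yet measured. It shares the core of compound 3 and differs from it in one place: a group of 9 heavy atoms (7 carbon, 2 nitrogen; one five-membered aromatic ring with 1 hetero atom, one six-membered aromatic ring with 1 hetero atom) in place of a group of 11 heavy atoms (9 carbon, 1 nitrogen, 1 oxygen; one five-membered aromatic ring with 1 hetero atom, one six-membered aromatic ring of carbon only), on a saturated ring carbon. Within the data shown here, no pair of measured compounds separates this change on its own, so its effect has to be judged from the whole set. Compound 2 and compound 3 carry different groups at this same saturated ring carbon and at other places too, and their numbers in this assay lie within the scatter of each other, which suggests that this part of the molecule tolerates some variation without a large shift.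

The account continues once the measurement for compound 4 is known.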

Compound 4, half-maximal inhibitory concentration: 58 nM
Estimate against measurement, compound 4: 1.4-fold (0.14 log units) above; low and high end bracket the measured number.
By their numbers in this assay, from the lowest: compounds 3, 2 and 4 (each within the scatter of the next); then compound 1.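

In this assay, among these compounds, the exchange of the 5-methoxy-1H-indol-3-yl group for the group with a hetero atom in its six-membered aromatic ring gives a 2.0-fold higher number from compound 3 to compound 4 (0.30 log units; within the scatter) and is the first step in the set that isolates this saturated ring carbon. On an otherwise unchanged molecule, this place therefore accepts the loss of the methoxy group and a nitrogen in the six-membered aromatic ring together, with no shift that can be told from the scatter, while the counts of hydrogen-bond donors and acceptors stay the same on both sides. Nothing measured here gives a reason for this result.

Among the compounds shown here, the single step joins two alterations, so the share of the methoxy group cannot be separated from that of the ring nitrogen, and a plain 1H-indol-3-yl group, or a methoxy group carried on the ring that holds the second nitrogen, would be needed to pull them apart. Going by these compounds, how far the tolerance reaches also remains open, for instance whether a simple phenyl group, with no five-membered ring and no ring nitrogen, would hold its number at this saturated ring carbon.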